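Propyl on the Aromatic Nitrogen of Compound 1

The source may hold more compounds than are shown below. What is called first, only, known or untested is meant among the compounds shown, and "the series" means these compounds.

Compound 1, `COc1cc(C(=O)NS(=O)(=O)c2ccccc2)ccc1Cc1c[nH]c2ccc(NC(=O)OC3CCCC3)cc12`, gives 9.84 in an ADME assay for acid dissociation; on this read-out higher numbers stand for higher potency (the scale is a negative logarithm) and lower numbers for lower potency.
Compound 2, `COc1cc(C(=O)O)ccc1Cc1c[nH]c2ccc(NC(=O)OC3CCCC3)cc12`, gives 7.32 in this assay.

Compound 1 stands highest of the two measured numbers; its nearest neighbour is compound 2, and the step of a number 2.52 log units lower from compound 1 to compound 2 (beyond the scatter) lies beyond the scatter. Compound 3, `CCCn1cc(Cc2ccc(C(=O)NS(=O)(=O)c3ccccc3)cc2OC)c2cc(NC(=O)OC3CCCC3)ccc21`, has not yet been measured. It differs from compound 1 by propyl in place of hydrogen on an aromatic nitrogen. Going by the values given here, the only measured step, a number 2.52 log units lower from compound 1 to compound 2 (beyond the scatter), concerns the carbonyl carbon and the groups that sit on it, which are kept in compound 3, so no measured step touches the aromatic nitrogen. Without a comparable step, no shift beyond the scatter is expected for compound 3 in this assay, and the estimated step is a number 0.14 log units lower from compound 1 to compound 3 (within the scatter). Compound 3 is therefore estimated at 9.7, within 9 to 10.3, in this assay.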

Compound 3, negative logarithm of the antagonist equilibrium constant: 8.44
For compound 3 the middle estimate is 1.26 log units above the measured one, outside the stated range (below it).
By their numbers in this assay, from the lowest: compound 2; then compound 3; then compound 1.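

The aromatic nitrogen of the five-membered aromatic ring proves not to be a neutral position: in this assay, propyl in place of hydrogen there gives a number 1.40 log units lower from compound 1 to compound 3 (beyond the scatter). Going by these compounds alone, this is the first measured change away from the carbonyl carbon, and it shows that the group on this nitrogen alone can move the number beyond the scatter while the phenylsulfonyl amide stays in place. No measurement at hand gives a reason for this step.

From the compounds shown here alone, whether a smaller group such as methyl or a longer chain such as butyl on this nitrogen would give a smaller or larger step remains open. So does whether propyl would have a similar effect on compound 2, which carries the carboxylic acid.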